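Changing the Aryl on the Oxygen: Compound 4 Expected

This account rests on a few compounds, and the source may have more. Where it says the series, first, only, none or still open, it means among the compounds named here.

Compound 1, `Cc1nn(Cc2ccccc2C(N)=O)c(C)c1NC(=O)c1ccc(COc2ccccc2)cc1`: 42000 nM
Compound 2, `Cc1nn(Cc2cccc(C(=O)N(C)C)c2)c(C)c1NC(=O)c1ccc(COc2ccccc2)cc1`: 6400 nM
Compound 3, `CNC(=O)c1cccc(Cn2nc(C)c(NC(=O)c3ccc(COc4ccc(C)cc4)cc3)c2C)c1`: 2600 nM

All three compounds were measured in a functional assay on MIA PaCa-2 cells (Homo sapiens) for antiproliferative activity, read by MTT assay, with a stated time of 72 h; on this read-out lower numbers stand for an effect already at smaller amounts and higher numbers for an effect only at larger amounts of compound. Compound 3 stands lowest of the three numbers; compound 2 is nearest and compound 1 furthest, and both gaps lie beyond the scatter. For the measured compounds named here, the only step between compounds that differ in a single place is a 6.6-fold lower number from compound 1 to compound 2 (0.82 log units; beyond the scatter), a change at the saturated chain carbon bound to an aromatic nitrogen, far from the oxygen end of the molecule.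

Compound 4, `CNC(=O)c1cccc(Cn2nc(C)c(NC(=O)c3ccc(COc4ccc(C(F)(F)F)cc4C)cc3)c2C)c1`, differs from compound 3 by 2-methyl-4-(trifluoromethyl)phenyl in place of 4-methylphenyl on an oxygen on a saturated carbon. Going by the values given here, no measured step bears on this position: compounds 1 and 2 carry an unsubstituted phenoxy, but each also differs from compound 3 at the other end, so their values show nothing isolated about the group on the oxygen. The data therefore give no ground to expect a step beyond the scatter, and the expected step is a 1.2-fold lower number from compound 3 to compound 4 (0.07 log units; within the scatter). Compound 4 is estimated at 2200 nM, expected to fall between 600 nM and 8000 nM.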

Compound 4, half-maximal effective concentration: 620 nM
Estimate against measurement, compound 4: 3.5-fold (0.55 log units) above; low and high end bracket the measured number.
By their numbers in this assay, from the lowest: compound 4; then compound 3; then compound 2; then compound 1.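

In this assay, for the compounds shown here, the group on the oxygen turns out to matter: 2-methyl-4-(trifluoromethyl)phenyl in place of 4-methylphenyl gives a 4.2-fold lower number from compound 3 to compound 4 (0.62 log units; beyond the scatter) with the rest of the molecule unchanged, the first step to isolate this position. The entering group differs from the leaving one in two ways at once, an added methyl and a trifluoromethyl, so this single step cannot divide its size between them. Nothing measured here explains the step. Still open, as far as these compounds go, is whether 2-methylphenyl or 4-(trifluoromethyl)phenyl alone would account for it, and how a 4-chlorophenyl or a 4-methoxyphenyl would compare on the same oxygen. Also open, from the compounds shown here alone, is whether the same step would appear with the dimethylcarbamoyl group of compound 2 at the other end of the molecule.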